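Compound 4: dimethylcarbamoyl in place of hydrogen

A few compounds are considered here, and "the series" means these few. Any claim that something is new, unique, unknown or untested is made for them only; others in the source may bear on it.

compound 1 `CN1CCCc2ccc(NC(=O)c3ccc(-c4ccccc4)cc3)cc21` — 7.5
compound 2 `CN(C)CCN1CCCc2ccc(NC(=O)c3ccc(-c4ccccc4)cc3)cc21` — 7.4
compound 3 `COCC(=O)N1CCCc2ccc(NC(=O)c3ccc(-c4ccccc4)cc3)cc21` — 7.2

In a functional assay for antagonist activity at transient receptor potential cation channel subfamily V member 1 (Homo sapiens), read by FLIPR and calcium flux (on this read-out lower numbers stand for lower potency and higher numbers for higher potency (the scale is a negative logarithm)), compound 1 gives 7.5, the highest of the three numbers, though both of its steps lie within the scatter: a number 0.10 log units lower from compound 1 to compound 2 (within the scatter) and a number 0.30 log units lower from compound 1 to compound 3 (within the scatter). Compound 4 `CN(C)C(=O)c1ccc(-c2ccc(C(=O)Nc3ccc4c(c3)N(C)CCC4)cc2)cc1` differs from compound 1 in dimethylcarbamoyl in place of hydrogen on an aromatic carbon. Among the compounds with values here, no measured step touches that ring; all three measured steps alter the nitrogen on the aromatic ring in a ring of the shared core, and each stays within the scatter, including a number 0.20 log units lower from compound 2 to compound 3 (within the scatter). Within the data shown here, no measured step bears directly on this change, so no movement beyond the scatter is expected in this assay, with a wide range to allow for the lack of precedent. The step expected for compound 4 is a number 0.20 log units lower from compound 1 to compound 4 (within the scatter). Compound 4 is thus estimated at 7.3, with a range from 6.5 to 8.1.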

Compound 4, negative logarithm of the antagonist equilibrium constant: 7.1
Estimate against measurement, compound 4: 0.20 log units above; low and high end bracket the measured number.
By their numbers in this assay, from the lowest: compounds 4, 3, 2 and 1 (each within the scatter of the next, the first and the last beyond it).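

In this assay, dimethylcarbamoyl on this aromatic carbon, para to a large group, gives a number 0.40 log units lower from compound 1 to compound 4 (beyond the scatter), a modest step but the only one shown that lies beyond the scatter. Within the data shown here, the earlier steps all altered the nitrogen of the shared core and stayed within the scatter, so this is the first reading at this position. No available evidence accounts for the step. Open, going by these compounds, is whether a carboxylic acid, an amine or a primary carboxamide on this carbon moves the number as far. Also open, on these data alone, is whether the step holds with the nitrogen substituents of compound 2 or compound 3.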